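The source may report more compounds than this note shows. Statements on the series, on what has been measured and on what is new or still open speak of the compounds shown alone.

Measured in a physicochemical assay, with a stated time of 6 min; on this read-out lower numbers stand for stronger inhibition and higher numbers for weaker inhibition:
- Compound 1 `O=C(Nc1ccccc1)Nc1nc(-c2cc3cc([N+](=O)[O-])ccc3o2)cs1`: 183000 nM
- Compound 2 `COc1ccc(NC(=O)Nc2nc(-c3cc4cc(Br)ccc4o3)cs2)cc1`: > 200000 nM (a limit)
- Compound 3 `COc1cccc(NC(=O)Nc2nc(-c3cc4cc(Br)ccc4o3)cs2)c1`: > 200000 nM (a limit)

For compound 3 the result > 200000 nM is a limit and not a number. The small set is dominated by the limit of > 200000 nM in this assay, at which 2 of the 3 values shown sit.

Compound 4 `O=C(Nc1ccccc1)Nc1nc(-c2cc3cc(Br)ccc3o2)cs1` has hydrogen in place of methoxy on an aromatic carbon, meta to a large group, turning 3-methoxyphenyl into phenyl (hydrogen in place of methoxy on an aromatic carbon). Among the measured compounds shown here, the one measured step that bears on this is a step that the two limits leave unreadable from compound 2 to compound 3. It concerns the same methoxy group but gives no size to build on. Compound 1 also carries phenyl, and it alone has a true number, 183000 nM. Its core differs, so it offers only a rough guide.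

No shift beyond the usual scatter is therefore expected, and no direction can be called. In this assay the expected change is a step that the limit leaves unreadable from compound 3 to compound 4. For compound 4 the estimate is 210000 nM, with an expected range of 110000 nM to 400000 nM.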

Compound 4, half-maximal inhibitory concentration: > 200000 nM
Compound 4 ended at the assay's limit; the forecaster's own chance of this, stated with the estimate: 70%; the middle value does not contradict the limit.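

In this assay compound 4 gives > 200000 nM, a limit and not a number, so having hydrogen in place of methoxy on this ring does not yield a measurable value. The steps linking compound 4 to compound 2 and compound 3 cannot be read, and the limit now covers most of the set: the limit of > 200000 nM in this assay, at which 3 of the 4 values shown sit. Among the compounds shown here, the only readable step, for bromo in place of nitro on an aromatic carbon, is an at least 1.0-fold higher number from compound 1 to compound 4 (0.03 log units; that floor lies within the scatter), so it sets no order between these two groups.

On these data alone, how far methoxy and hydrogen truly differ at this position remains open, since limits give no size for that change. Also open, as far as these compounds go, is whether an amine or a carboxylic acid on this ring would give a true number in this assay.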